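Ether Chain in Place of Vinyl: Expected Cytotoxicity

This account rests on a few compounds, and the source may have more. Where it says the series, first, only, none or still open, it means among the compounds named here.

Compound 1, `C=CCn1c2ccc([N+](=O)[O-])cc2c(=O)n1Cc1ccccc1`: 192000 nM
Compound 2, `NC(=O)CCCn1c2ccc([N+](=O)[O-])cc2c(=O)n1Cc1ccccc1`: > 256000 nM, a limit of the test
Compound 3, `COCCn1c2ccc([N+](=O)[O-])cc2c(=O)n1Cc1ccccc1`: > 256000 nM, a limit of the test

All three share one core and differ only in the group on a saturated chain carbon bound to an aromatic nitrogen. They were read in an ADME assay on L929 cells (Mus musculus) for cytotoxicity, read by resazurin assay, with a stated time of 48 h; on this read-out lower numbers stand for higher toxicity in this test and higher numbers for lower toxicity in this test. Within the data shown here, compound 1 is the only one that gives a number. For compound 2 the reading is a limit of the test rather than a number. The same holds for compound 3. Two of the three readings therefore rest at the limit of > 256000 nM in this assay, at which 2 of the 3 values shown sit.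

The two measured steps away from compound 1 both point the same way: an at least 1.3-fold higher number from compound 1 to compound 2 (0.12 log units; that floor lies within the scatter), and an at least 1.3-fold higher number from compound 1 to compound 3 (0.12 log units; that floor lies within the scatter). Neither floor is large enough to count as a real change, so the three compounds look alike within the scatter.

Compound 4, `CCOCCCn1c2ccc([N+](=O)[O-])cc2c(=O)n1Cc1ccccc1`, is not yet measured. Against compound 1 the change is 2-ethoxyethyl in place of vinyl on a saturated chain carbon bound to an aromatic nitrogen. Like compound 3, it carries an oxygen-bearing chain in this place, and compound 3 went to the limit. A small move toward lower toxicity, or none beyond the scatter, is expected: a 1.3-fold higher number from compound 1 to compound 4 (0.12 log units; within the scatter). Compound 4 is thus estimated at 256000 nM, within 150000 nM to 450000 nM, with a fair chance that only a limit is reported.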

Compound 4, concentration lethal to 50% of the cells: 170000 nM
Compound 4: the middle estimate sits 1.5-fold (0.18 log units) above what was measured, within the range that was stated.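

Unlike compound 3, compound 4 carries an ether chain at this place and still gives a real number in this assay, so this change can be read directly against vinyl, as a 1.1-fold lower number from compound 1 to compound 4 (0.05 log units; within the scatter). Against the two compounds that rest at a limit, the steps are an at least 1.5-fold lower number from compound 3 to compound 4 (0.17 log units; that floor lies within the scatter) and an at least 1.5-fold lower number from compound 2 to compound 4 (0.17 log units; that floor lies within the scatter), and neither floor is large enough to count as a real change. An ether chain at this place therefore does not by itself bring a compound to the limit, as compound 3 alone might have suggested, and going from allyl to 3-ethoxypropyl leaves the reading indistinguishable from that of compound 1.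

The true distance of compound 2 and compound 3 from the other two cannot be sized, because their readings are limits rather than numbers: the limit of > 256000 nM in this assay, at which 2 of the 4 values shown sit. On these data alone, it also remains open how this position would respond to an amine, a carboxylic acid or a plain propyl chain with no oxygen and no double bond.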